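A 3-methylpiperidin-1-yl swap at the solubility limit

The compounds below may be only part of what the source reports. "The series", "measured", "known", "first", "only" and "open" are said of these compounds alone.

In a physicochemical assay for solubility (a lower number here means a less soluble compound, a higher number a more soluble compound), compound 1 `CS(=O)(=O)c1ccc(-n2nc(C(F)(F)F)c(C#N)c2-c2ccccc2)nc1` gives 100 ug/mL. Compound 2 `C[C@@H]1CN(c2c(C#N)c(C(F)(F)F)nn2-c2ccc(S(C)(=O)=O)cn2)[C@H](C)CO1` gives > 200 ug/mL, which is a limit and not a number. Compound 3 `C[C@@H]1CN(c2c(C#N)c(C(F)F)nn2-c2ccc(S(C)(=O)=O)cn2)[C@H](C)CO1` gives > 200 ug/mL, also a limit. Two of the three results therefore stand at the same ceiling: the limit of > 200 ug/mL in this assay, at which 2 of the 3 values shown sit.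

Compound 4 `CC1CCCN(c2c(C#N)c(C(F)(F)F)nn2-c2ccc(S(C)(=O)=O)cn2)C1` differs from compound 2 as follows: a group of 7 heavy atoms (6 carbon, 1 nitrogen; one six-membered non-aromatic ring with 1 hetero atom) in place of a group of 8 heavy atoms (6 carbon, 1 nitrogen, 1 oxygen; one six-membered non-aromatic ring with 2 hetero atoms), on an aromatic carbon. Two measured steps are available. The step of an at least 2.0-fold higher number from compound 1 to compound 2 (0.30 log units; that floor lies within the scatter) changes the group on the same aromatic carbon, but its floor lies within the scatter. The step that the two limits leave unreadable from compound 2 to compound 3 lies elsewhere on the molecule, and its size cannot be read, so it offers no guide.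

Among the compounds with values here, the only firm number nearby is that of compound 1, at 100 ug/mL, so a modest fall is expected, with its size poorly defined. The estimated change is an at least 1.6-fold lower number from compound 2 to compound 4 (0.22 log units; that floor lies within the scatter). For compound 4 the expected value is 120 ug/mL, with an estimated range from 40 ug/mL to 200 ug/mL.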

Compound 4, solubility: 100 ug/mL
The estimate for compound 4 lay 1.2-fold (0.08 log units) above the measured number; low and high end bracket the measured number.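

With the 3-methylpiperidin-1-yl group, compound 4 gives the only firm number among the compounds shown that carry a non-aromatic ring on this aromatic carbon, and in this assay the swap for the two-hetero-atom ring reads as an at least 2.0-fold lower number from compound 2 to compound 4 (0.30 log units; that floor lies within the scatter). Compound 2 holds a limit and not a number, the same ceiling that compound 3 holds: the limit of > 200 ug/mL in this assay, at which 2 of the 4 values shown sit. Set against phenyl on the same carbon, the 3-methylpiperidin-1-yl group gives no change at the digits printed from compound 1 to compound 4 (within the scatter), so these two groups cannot be told apart in this read-out.

The true size of the step from the two-hetero-atom ring cannot be read, as only its floor is known. Also open, from the compounds shown here alone, is how a piperazin-1-yl ring or an unsubstituted piperidin-1-yl group would read on this carbon.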